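Methylsulfanyl for fluoro: working notes on the series

This account rests on a few compounds, and the source may have more. Where it says the series, first, only, none or still open, it means among the compounds named here.

In an in vivo ADME assay on the whole organism for pharmacokinetics, with Mus musculus as the target, at a dose of 200 mg/kg by the intraperitoneal route (on this read-out higher numbers stand for higher exposure at the dose given and lower numbers for lower exposure), compound 1 `CSc1ccc(C2=C(c3ccc(C)cc3)C(=O)N3CCCC3C2)cc1` gives 8020 nM, and compound 2 `CSc1ccc(C2=C(c3ccc(F)cc3)C(=O)N3CCCC3C2)cc1` gives 990 nM. Among the measured compounds shown here, compound 2 therefore holds the lower of the two numbers measured so far.

The next structure is compound 3 `CSc1ccc(C2=C(c3ccc(SC)cc3)C(=O)N3CCCC3C2)cc1`, which has methylsulfanyl in place of fluoro on an aromatic carbon, para to a large group: methylsulfanyl in place of fluoro on an aromatic carbon.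

For the measured compounds named here, one measured step bears on this change: an 8.1-fold lower number from compound 1 to compound 2 (0.91 log units; beyond the scatter), where fluoro replaces methyl at the same place. Going by the values given here, this is a single pair, and no measured compound carries methylsulfanyl at this place, so the size of the new step is poorly constrained. A rise in this assay is expected, based on compound 1, which has methyl at this place and gives 8020 nM. That rise is expected to be smaller than the measured step, and a result within the scatter cannot be excluded.

The expected change is a 3.0-fold higher number from compound 2 to compound 3 (0.48 log units; beyond the scatter). For compound 3, the estimate is 3000 nM, with an expected range of 800 nM to 11000 nM.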

Compound 3, maximal plasma concentration: 860 nM
Beside the measured number, compound 3's estimate is 3.5-fold (0.54 log units) above it; the range from low to high includes it.
By their numbers in this assay, from the lowest: compounds 3 and 2 (each within the scatter of the next); then compound 1.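

In this assay, replacing fluoro with methylsulfanyl on this aromatic carbon gives a 1.2-fold lower number from compound 2 to compound 3 (0.06 log units; within the scatter) and so leaves the number within the scatter, which the earlier pair could not show. Replacing methyl with methylsulfanyl at the same place gives a 9.3-fold lower number from compound 1 to compound 3 (0.97 log units; beyond the scatter) as a step beyond the scatter, and it is of much the same size as the fluoro step an 8.1-fold lower number from compound 1 to compound 2 (0.91 log units; beyond the scatter) at this place. Among the three groups tried here, methyl alone therefore sets its compound apart, while fluoro and methylsulfanyl cannot be told apart on this read-out, and nothing available accounts for that difference.

Whether the higher exposure is specific to methyl remains open, as the compounds shown do not reveal how an ethyl group or a longer chain, a chloro group, an amine or a carboxylic acid would behave at this place. Also open, on these data alone, is whether the same ordering of methyl, fluoro and methylsulfanyl would hold with the methylsulfanyl group on the other aromatic ring of the shared core replaced.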